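The compounds below may be only part of what the source reports. "The series", "measured", "known", "first", "only" and "open" are said of these compounds alone.

Compound 1, `Cc1cc2ccccc2nc1-c1cn(-c2ccc(F)cc2)nn1`, in a functional assay on COLO 205 cells (Homo sapiens) for cytotoxicity, read by MTT assay, with a stated time of 24 h; a higher number here means a weaker inhibitor, a lower number a stronger inhibitor: compound 1 gives > 100 ug/mL, a limit of the assay rather than a number.
Compound 2, `CCCCCCCCCCn1cc(-c2nc3ccccc3cc2CC)nn1`: compound 2 gives > 100 ug/mL, also a limit.
Compound 3, `CCCCCCCCCCn1cc(-c2nc3ccccc3cc2CCC)nn1`: compound 3 gives > 100 ug/mL, again a limit.

Compound 1 thus stands only at a limit, with no number of its own; every value shown sits at the limit of > 100 ug/mL in this assay, at which 3 of the 3 values shown sit. Going by the values given here, the single measured step, a step that the two limits leave unreadable from compound 2 to compound 3, cannot be read: both of its ends are limits. The change that leads to compound 4, `CCc1cc2ccccc2nc1-c1cn(-c2ccc(F)cc2)nn1`, is methyl in place of hydrogen on a saturated chain carbon bound to an aromatic carbon. Among the compounds with values here, the one step that adds a methyl, from compound 2 to compound 3, bears on this change, yet its size is unreadable, so it supports no expectation of a step beyond the scatter in either direction. Compound 4 is therefore estimated at 150 ug/mL, with a range from 50 ug/mL to 500 ug/mL. The step this estimate means, a step that the limit leaves unreadable from compound 1 to compound 4, is expected to be none beyond the scatter, most likely ending at a limit once more.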

Compound 4, half-maximal inhibitory concentration: > 100 ug/mL
Compound 4: only a limit was reported (the forecaster's own chance of this, stated with the estimate: 85%); the middle value is on the limit's open side.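

Compound 1 and compound 4 are both reported only as limits in this assay, so the step between them cannot be read. The compounds shown leave open whether this methyl changes cytotoxicity at all, and how strong any of them truly is, because all stop at one limit: the limit of > 100 ug/mL in this assay, at which 4 of the 4 values shown sit.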